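Swapping the 4-aminophenyl group of compound 2

A few compounds are considered here, and "the series" means these few. Any claim that something is new, unique, unknown or untested is made for them only; others in the source may bear on it.

Compound 1 `O=C(Nc1cccc(F)c1)c1cc(=O)[nH]c2cc(-c3ccsc3)ccc12` gives 4300 nM in a functional assay on KYSE-410 cells (Homo sapiens) for antiproliferative activity, read by MTT assay, with a stated time of 72 h; a lower number here means a stronger inhibitor, a higher number a weaker inhibitor. Compound 2 `Nc1ccc(-c2ccc3c(C(=O)Nc4cccc(F)c4)cc(=O)[nH]c3c2)cc1` gives > 20000 nM in this assay, and this is a limit of the assay, not a number. Compound 3 `Cc1cc(-c2ccc3c(C(=O)Nc4cccc(F)c4)cc(=O)[nH]c3c2)c(C)cc1F` differs from compound 2 in one place: 4-fluoro-2,5-dimethylphenyl in place of 4-aminophenyl on an aromatic carbon. Here, 4-fluoro-2,5-dimethylphenyl takes the place of 4-aminophenyl on an aromatic carbon.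

Among the compounds with values here, one measured step bears on this change: an at least 4.6-fold higher number from compound 1 to compound 2 (0.66 log units; beyond the scatter), beyond the scatter, when 4-aminophenyl replaced thiophen-3-yl. Within the data shown here, that single step shows only that a change here can move the number. With 4-aminophenyl gone, compound 3 is expected to move back towards compound 1 at 4300 nM, without necessarily reaching it. The expected change is modest and towards a lower number, an at least 2.5-fold lower number from compound 2 to compound 3 (0.39 log units; beyond the scatter). For compound 3, the estimated value is 8000 nM, with an expected range of 2500 nM to 20000 nM.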

Compound 3, half-maximal inhibitory concentration: > 20000 nM
Compound 3 gave a limit, no number; the forecaster's own chance of this, stated with the estimate: 25%; middle value at least 2.5-fold (0.39 log units) from the limit.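

Compound 3 gives > 20000 nM in this assay, and this is a limit of the assay, not a number. With 4-fluoro-2,5-dimethylphenyl in place of thiophen-3-yl, the result is an at least 4.6-fold higher number from compound 1 to compound 3 (0.66 log units; beyond the scatter), so the loss seen with compound 2 also appears with a substituted phenyl group that has no amine and 0 hydrogen-bond donors. The amine of compound 2 is therefore not needed for a result at the limit, and among the compounds shown only thiophen-3-yl gives a readable number; the step between compound 2 and compound 3 cannot be read because both compounds stop at the same ceiling: the limit of > 20000 nM in this assay, at which 2 of the 3 values shown sit.

Going by these compounds, how far either compound lies past that limit remains unknown. Also open, on these data alone, is whether an unsubstituted phenyl ring or a thiophen-2-yl group at this position would give a readable number.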